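The source may hold more compounds than are shown below. What is called first, only, known or untested is meant among the compounds shown, and "the series" means these compounds.

Measured compounds:
compound 1, `CCN1CCN(S(=O)(=O)c2ccc(NC(=O)C3C(C(=O)O)[C@H]4CC[C@@H]3O4)cc2)CC1`, gives 27400 nM in a functional assay on HCT-8 cells (Homo sapiens) for cytotoxicity, read by MTT assay, with a stated time of 48 h; on this read-out lower numbers stand for stronger inhibition and higher numbers for weaker inhibition
compound 2, `O=C(Nc1ccc(S(=O)(=O)NC2CCCCC2)cc1)C1C(C(=O)O)[C@H]2CC[C@@H]1O2`, gives 31000 nM in this assay
compound 3, `O=C(Nc1ccc(S(=O)(=O)NC2CCCC2)cc1)C1C(C(=O)O)[C@H]2CC[C@@H]1O2`, gives 30200 nM in this assay

Compound 3 stands second highest of the three numbers, but its nearest neighbour is compound 2, with a 1.0-fold lower number from compound 2 to compound 3 (0.01 log units; within the scatter), and its furthest is compound 1, with a 1.1-fold higher number from compound 1 to compound 3 (0.04 log units; within the scatter); all three values lie within the scatter of one another, so no order among them can be read.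

Compound 4, `O=C(Nc1ccc(S(=O)(=O)NC2CC2)cc1)C1C(C(=O)O)[C@H]2CC[C@@H]1O2`, is the next step from compound 3. The change is cyclopropyl in place of cyclopentyl on a sulfonamide nitrogen. Among the compounds with values here, two measured steps bear on it, since both alter the group on the same sulfonamide nitrogen: a 1.1-fold higher number from compound 1 to compound 2 (0.05 log units; within the scatter) and a 1.0-fold lower number from compound 2 to compound 3 (0.01 log units; within the scatter). Neither went beyond the scatter, so the group carried by that nitrogen has so far left the numbers in this assay unmoved. A smaller ring in that place is a change of the same kind, and the expectation is therefore no step beyond the scatter, in either direction.

On that basis compound 4 is estimated at 30000 nM in this assay, with a range from 15000 nM to 60000 nM. The step this estimate implies is a 1.0-fold lower number from compound 3 to compound 4 (0.00 log units; within the scatter), expected to stay within the scatter.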

Compound 4, half-maximal inhibitory concentration: 28300 nM
Beside the measured number, compound 4's estimate is 1.1-fold (0.03 log units) above it, and the stated range covers the measured number.
By their numbers in this assay, from the lowest: compounds 1, 4, 3 and 2 (each within the scatter of the next).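

Compound 4 takes the ring on the sulfonamide nitrogen down to a three-membered one, and it shows that cyclopentyl can give way to this much smaller ring without the number in this assay moving beyond the scatter (a 1.1-fold lower number from compound 3 to compound 4 (0.03 log units; within the scatter)). The same holds against the cyclohexyl compound (a 1.1-fold lower number from compound 2 to compound 4 (0.04 log units; within the scatter)) and against the 4-ethylpiperazin-1-yl compound (a 1.0-fold higher number from compound 1 to compound 4 (0.01 log units; within the scatter)), so the values of all four compounds cannot be put in any order, and none of them goes against this flat picture. No available evidence bears on this flat result.

As far as these compounds go, it remains open whether a group other than a non-aromatic ring of carbon only would shift the number at this place, such as a phenyl ring, a longer alkyl chain, or a cyclohexyl ring bearing an amine or a hydroxyl. From the compounds shown here alone, all four compounds also keep the carboxylic acid and the shared core, so what an ester or a primary amide in place of that acid would do in this assay is equally open.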